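The source may hold more compounds than are shown below. What is called first, only, known or untested is meant among the compounds shown, and "the series" means these compounds.

Measured compounds in a functional assay on HepG2 cells (Homo sapiens) for antiproliferative activity, read by MTT assay, with a stated time of 48 h; a higher number here means a weaker inhibitor, a lower number a stronger inhibitor:
Compound 1 `Cc1cccc(-n2nncc2CN2C(=O)C3(C(C#N)=C(N)Oc4c(N)cc5nc6ccccc6nc5c43)c3ccccc32)c1` gives > 50000 nM, which is a limit of the assay rather than a number.
Compound 2 `CCOc1ccc(-n2nncc2CN2C(=O)C3(C(C#N)=C(N)Oc4c(N)cc5nc6ccccc6nc5c43)c3ccccc32)cc1` gives > 50000 nM, likewise only a limit.

Compound 2 therefore stands only at a limit in this assay; no actual number is known for it. Within the data shown here, the single measured step, a step that the two limits leave unreadable from compound 1 to compound 2, runs between two limits and its size cannot be read. The change now considered is 3,4-dimethylphenyl in place of 4-ethoxyphenyl on an aromatic nitrogen, which gives compound 3 `Cc1ccc(-n2nncc2CN2C(=O)C3(C(C#N)=C(N)Oc4c(N)cc5nc6ccccc6nc5c43)c3ccccc32)cc1C`. Since both measured compounds sit at the same limit (the limit of > 50000 nM in this assay, at which 2 of the 2 values shown sit), compound 3 is expected to sit there as well, the expected step being a step that the limit leaves unreadable from compound 2 to compound 3. The estimate for compound 3 is 70000 nM, within 30000 nM to 200000 nM.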

Compound 3, half-maximal inhibitory concentration: > 50000 nM
Compound 3 ended at the assay's limit (the forecaster's own chance of this, stated with the estimate: 85%); the middle value lies beyond the limit too.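

Compound 3 gives only a limit, so its steps from compound 1 and compound 2 cannot be read: the limit of > 50000 nM in this assay, at which 3 of the 3 values shown sit.

Left open is whether any group on this aromatic nitrogen would give the shared core an actual number in this assay rather than a limit.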